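The source may hold more compounds than are shown below. What is called first, only, known or untested is meant among the compounds shown, and "the series" means these compounds.

Measured in a functional assay on HeLa cells (Homo sapiens) for cytotoxicity, read by XTT assay, with a stated time of 72 h; a higher number here means a weaker inhibitor, a lower number a stronger inhibitor:

- compound 1 `CCn1ccc2cc(Cc3cc(OC)c(OC)c(OC)c3)ccc21` gives 17 nM
- compound 2 `COc1ccc(Cc2ccc3ccccc3c2)c(OC)c1OC` gives 200 nM
- compound 3 `COc1ccc(Cc2cc(OC)c(OC)c(OC)c2)cc1O` gives 2.9 nM

Compound 1 holds the middle place of these three numbers. Compound 3 lies lower and compound 2 higher, with both gaps beyond the usual scatter. The unmeasured compound 4 `COc1cc(Cc2ccc3c(ccn3C)c2)cc(OC)c1OC` differs from compound 1 in one place (hydrogen in place of methyl on a saturated chain carbon bound to an aromatic nitrogen), with hydrogen in place of methyl on a saturated chain carbon bound to an aromatic nitrogen. Going by the values given here, no measured pair shows this change, so the estimate starts from compound 1 at 17 nM and allows for only a small shift. The expected 1.5-fold lower number from compound 1 to compound 4 (0.19 log units; within the scatter) stays within the scatter, leaning slightly towards a lower number. For compound 4 the estimated value is 11 nM, with an expected range from 3 nM to 40 nM.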

Compound 4, half-maximal inhibitory concentration: 30 nM
Beside the measured number, compound 4's estimate is 2.7-fold (0.44 log units) below it; low and high end bracket the measured number.
By their numbers in this assay, from the lowest: compound 3; then compounds 1 and 4 (each within the scatter of the next); then compound 2.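

In this assay, going by these compounds alone, the ethyl to methyl change on the aromatic nitrogen gives a 1.8-fold higher number from compound 1 to compound 4 (0.25 log units; within the scatter) and so offers the first direct reading at this position. Ethyl and methyl cannot be told apart here, so this small trim of the chain leaves the number essentially in place. Nothing available explains this result.

The compounds shown leave open how a longer chain such as butyl would read at this position. They also leave open the effect of a chain ending in an amine or a carboxylic acid.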